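Swapping 4-bromophenyl for 4-methylbenzyl on a sulfonyl sulfur

A few compounds are considered here, and "the series" means these few. Any claim that something is new, unique, unknown or untested is made for them only; others in the source may bear on it.

Compound 1 `COc1ccccc1/C=C(\C(=O)c1ccc(Cl)cc1)S(=O)(=O)c1ccc(C)cc1`: 1000 nM
Compound 2 `Cc1ccc(CS(=O)(=O)/C(=C/c2cccc(Cl)c2Cl)C(=O)c2ccc(Cl)cc2)cc1`: 1000 nM
Compound 3 `COc1ccccc1/C=C(\C(=O)c1ccc(Cl)cc1)S(=O)(=O)c1ccc(Br)cc1`: 10000 nM

In a functional assay on DU-145 cells (Homo sapiens) for inhibition, read by trypan blue exclusion, with a stated time of 96 h (a higher number here means a weaker inhibitor of growth, a lower number a stronger inhibitor of growth), compound 3 has the highest number of the three, 10000 nM, making it the weakest inhibitor here. Compound 4 `COc1ccccc1/C=C(\C(=O)c1ccc(Cl)cc1)S(=O)(=O)Cc1ccc(C)cc1` differs from it as follows: 4-methylbenzyl in place of 4-bromophenyl on a sulfonyl sulfur. In short, 4-methylbenzyl stands in place of 4-bromophenyl on a sulfonyl sulfur. Within the data shown here, one measured step bears on this: a 10-fold higher number from compound 1 to compound 3 (1.00 log units; beyond the scatter), with bromo in place of methyl on an aromatic carbon. Compound 4 carries methyl, not bromo, and compound 2, which also has 4-methylbenzyl, gives 1000 nM. Neither comparison is exact, so the range stays wide. Similar in size to that step and towards a lower number, the change is expected to be a 10-fold lower number from compound 3 to compound 4 (1.00 log units; beyond the scatter). The estimate for compound 4 is 1000 nM, with a range of 250 nM to 5000 nM.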

Compound 4, concentration for 50% growth inhibition: 10000 nM
Estimate against measurement, compound 4: 10-fold (1.00 log units) below, and the stated range ends below it.
By their numbers in this assay, from the lowest: compounds 1 and 2 (each within the scatter of the next); then compounds 3 and 4 (each within the scatter of the next).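

In this assay, 4-methylbenzyl on the sulfonyl sulfur brings no gain over 4-bromophenyl, with no change at the digits printed from compound 3 to compound 4 (within the scatter), and it loses ground against the 4-methylphenyl group, with a 10-fold higher number from compound 1 to compound 4 (1.00 log units; beyond the scatter). Keeping 4-methylbenzyl and placing 2-methoxyphenyl where 2,3-dichlorophenyl stood gives a 10-fold higher number from compound 2 to compound 4 (1.00 log units; beyond the scatter), so the value of 4-methylbenzyl depends on the group on the double-bonded chain carbon. Nothing shown here explains these results. On these data alone, how a longer chain or an amine on the sulfonyl sulfur would fare remains open, as does how 4-methylphenyl would behave alongside 2,3-dichlorophenyl.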